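The source may hold more compounds than are shown below. What is called first, only, known or untested is meant among the compounds shown, and "the series" means these compounds.

Values in a functional assay on MDA-MB-435 cells (Homo sapiens) for cytotoxicity, read by MTT assay, with a stated time of 72 h (on this read-out higher numbers stand for weaker inhibition and lower numbers for stronger inhibition), so far:
- compound 1 (`COc1ccc(CNC(=O)c2nc(Br)c3cccnc3c2N[C@H]2CC[C@H](N)CC2)cc1`) gives 5000 nM as a measured number
- compound 2 (`O=C(NCc1ccc(F)cc1)c1nc(Br)c2cccnc2c1NCCO`) gives > 20000 nM as a limit
- compound 3 (`C[C@H](Nc1c(C(=O)NCc2ccc(F)cc2)nc(Br)c2cccnc12)c1ccccc1`) gives > 20000 nM as a limit

Going by the values given here, compound 1 at 5000 nM holds the only actual number in the set. Compound 2 and compound 3 both report only a limit (the limit of > 20000 nM in this assay, at which 2 of the 3 values shown sit).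

Compound 4 (`N[C@H]1CC[C@H](Nc2c(C(=O)NCc3ccc(Cl)cc3)nc(Br)c3cccnc23)CC1`) departs from compound 1 at one place (chloro in place of methoxy on an aromatic carbon), where 4-methoxybenzyl becomes 4-chlorobenzyl. Among the compounds with values here, no measured step covers this exchange. Within the data shown here, the one step available (a step that the two limits leave unreadable from compound 2 to compound 3) is a change at a different place and has no readable size to carry over.

The expectation therefore rests on compound 1 at 5000 nM alone: no step beyond the usual scatter is expected in this assay and neither direction is favoured. The estimated change is no change at the digits printed from compound 1 to compound 4 (within the scatter) on this reasoning. Compound 4 is estimated at 5000 nM with an expected range from 2000 nM to 12500 nM on this basis.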

Compound 4, half-maximal inhibitory concentration: 1000 nM
Compound 4: the middle estimate sits 5.0-fold (0.70 log units) above what was measured, and the stated range ends above it.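

In this assay, the aromatic carbon carrying the substituent on the benzyl group responds to exchange with the rest of the molecule held constant: chloro in place of methoxy gives a 5.0-fold lower number from compound 1 to compound 4 (0.70 log units; beyond the scatter). This is the first readable size for any change in the series, as the only earlier step runs between two compounds that report limits and cannot be read: the limit of > 20000 nM in this assay, at which 2 of the 4 values shown sit. No measurement shown gives a reason for this step.

On these data alone, how a nitrile, a trifluoromethyl or an amine would read on the same aromatic carbon remains open. Also open, as far as these compounds go, is whether the methoxy to chloro exchange carries the same size when the nitrogen on the core bears 2-hydroxyethyl or 1-phenylethyl.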